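Microsomal half-life notes on compounds 1 to 4

The compounds below may be only part of what the source reports. "The series", "measured", "known", "first", "only" and "open" are said of these compounds alone.

Measured so far, each in an in vitro ADME assay on microsomes from liver (Homo sapiens) for metabolic stability, read by LC-MS, tested at 1 uM; on this read-out higher numbers stand for a longer-lived compound and lower numbers for a shorter-lived compound:
- compound 1 `CC(C)N/C(=N\c1nccn1C(C)C)Nc1ccc(Cl)c(Cl)c1` gives 0.375 h.
- compound 2 `CC(C)n1ccnc1/N=C(/Nc1ccc(Cl)c(Cl)c1)NC(C)(C)C` gives 0.673 h.
- compound 3 `CC(C)n1ccnc1/N=C(/NC(=O)C(C)(C)C)Nc1ccc(Cl)c(Cl)c1` reaches only a limit of the assay, > 1 h, not a number.

The step from compound 1 to compound 2 is methyl in place of hydrogen on a saturated chain carbon bound to an amine nitrogen and two saturated chain carbons; in this assay it gives a 1.8-fold higher number from compound 1 to compound 2 (0.25 log units; within the scatter), so the two values cannot be ordered. Compound 3 sits at the limit of > 1 h in this assay, at which 1 of the 3 values shown sits. How the core of compound 3 differs from that of compound 1 is not broken down here.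

Compound 4 `CC(C)(C)C(=O)N/C(=N/c1nccn1C(C)(C)C)Nc1ccc(Cl)c(Cl)c1` is not yet measured. It differs from compound 3 by methyl in place of hydrogen on a saturated chain carbon bound to an aromatic nitrogen and two saturated chain carbons. This is the same kind of change as that from compound 1 to compound 2, but not the same: there the carbon was bound to an amine nitrogen, here to an aromatic nitrogen. Given that the earlier step stayed within the scatter (a 1.8-fold higher number from compound 1 to compound 2 (0.25 log units; within the scatter)), a step that the limit leaves unreadable from compound 3 to compound 4 is expected from compound 3 to compound 4, resting on compound 3 already standing at > 1 h. Compound 4 is therefore estimated at 1.5 h, between 0.7 h and 3 h, with a good chance that this assay again reports only a limit.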

Compound 4, half-life: > 1 h
Compound 4 gave a limit, no number; the forecaster's own chance of this, stated with the estimate: 60%; the middle value does not contradict the limit.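

Compound 4 gives > 1 h in this assay as a limit and not a number. No step can be read between compound 3 and compound 4, as both stand at the same limit: the limit of > 1 h in this assay, at which 2 of the 4 values shown sit. Still open, going by these compounds, is whether isopropyl to tert-butyl changes the half-life at all, and how far either compound lies past the limit.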